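Propyl to 3-methylphenyl on the ring nitrogen

The source may hold more compounds than are shown below. What is called first, only, known or untested is meant among the compounds shown, and "the series" means these compounds.

Measured so far in a functional assay on HT-29 cells (Homo sapiens) for antiproliferative activity, read by MTT assay, with a stated time of 72 h; a higher number here means a weaker inhibitor, a lower number a stronger inhibitor:
compound 1 (`CCCn1ccnc1-c1cc(OC)c(OC)c(OC)c1`) gives > 100000 nM as a limit
compound 2 (`COc1cc(-c2nccn2S(=O)(=O)c2ccccc2)cc(OC)c1OC`) gives > 100000 nM as a limit

Compound 1 stands at > 100000 nM in this assay, which is a limit and not a number. Compound 2 reads > 100000 nM in the same way, also a limit. Going by the values given here, the series so far shows the limit of > 100000 nM in this assay, at which 2 of the 2 values shown sit, and offers no measured step to scale from.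

Compound 3 (`COc1cc(-c2nccn2-c2cccc(C)c2)cc(OC)c1OC`) has 3-methylphenyl in place of propyl on an aromatic nitrogen of the shared core (3-methylphenyl in place of propyl on an aromatic nitrogen). Compound 1 gives only a limit, so a measurable change could run only toward a stronger inhibitor. The expected step is an at least 5.0-fold lower number from compound 1 to compound 3 (0.69 log units; beyond the scatter) in this assay, and a further limit reading remains quite possible. For compound 3 the estimate is 20000 nM (expected range 2000 nM to 100000 nM).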

Compound 3, half-maximal inhibitory concentration: 14600 nM
The estimate for compound 3 lay 1.4-fold (0.14 log units) above the measured number, within the range that was stated.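

Going by these compounds alone, on this aromatic nitrogen, 3-methylphenyl in place of propyl brings the series off its limit for the first time, with an at least 6.8-fold lower number from compound 1 to compound 3 (0.83 log units; beyond the scatter) in this assay. Compound 3 is thus the only compound shown with a measured number, so a measurable antiproliferative reading is reachable through this position with the rest of the shared core unchanged. The size of the step remains a floor and not a full measure, since the reading of compound 1 is a limit: the limit of > 100000 nM in this assay, at which 2 of the 3 values shown sit.

This single pair cannot tell whether the change in reading belongs to the aromatic ring or to its methyl. Plain phenyl would separate those two, and a benzyl group or 4-methylphenyl on the same nitrogen would test how much the reading depends on the link to the ring and on where the methyl sits.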